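Swapping a Cyclopropyl for a Fluorophenyl on the Amide

The source may hold more compounds than are shown below. What is called first, only, known or untested is meant among the compounds shown, and "the series" means these compounds.

Compound 1, `O=C(C1CCC1)N1CCCC1c1nc(-c2ccc(F)cc2)no1`: 2700 nM
Compound 2, `O=C(C1CC1)N1CCCC1c1nc(-c2cccc(F)c2)no1`: 2900 nM

Of the compounds shown here, two have been measured in an in vitro functional assay on HEK293-A cells for positive allosteric modulation of metabotropic glutamate receptor 5 (Homo sapiens), read by fluorescence and calcium flux, with a stated time of 140 s; a higher number here means that more compound is needed for the effect, a lower number that less compound is needed. Compound 2 has the larger of the two numbers, but its gap to compound 1 lies within the scatter of repeated measurements, so the two cannot be told apart on these data. Going by the values given here, the pair differ in two places at once, so no single step between measured compounds is available to guide a prediction.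

The next compound, compound 3, is `O=C(c1cccc(F)c1)N1CCCC1c1nc(-c2cccc(F)c2)no1`. It differs from compound 2 in one place: 3-fluorophenyl in place of cyclopropyl on a carbonyl carbon. Among the compounds with values here, no measured pair shows this kind of change, so the expected step from compound 2 to compound 3 rests on general experience rather than on these data. A moderate move toward a lower number is expected, of the size a 2.4-fold lower number from compound 2 to compound 3 (0.38 log units; beyond the scatter), though a step no larger than the scatter would not be surprising. Compound 3 is therefore estimated at 1200 nM in this assay, within a range from 300 nM to 5000 nM.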

Compound 3, half-maximal effective concentration: 2600 nM
Estimate against measurement, compound 3: 2.2-fold (0.34 log units) below; the measured number falls inside the stated range.
By their numbers in this assay, from the lowest: compounds 3, 1 and 2 (each within the scatter of the next).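

Putting 3-fluorophenyl, with 7 heavy atoms, in place of cyclopropyl, with 3 heavy atoms, on the carbonyl carbon gives a 1.1-fold lower number from compound 2 to compound 3 (0.05 log units; within the scatter) in this assay. The two groups therefore cannot be told apart at this place, so on this one pair a six-membered aromatic ring is accepted here as well as a three-membered non-aromatic ring. Nothing available bears on why this is so.

Still open, as far as these compounds go, is whether the fluorine of 3-fluorophenyl plays any part, which a plain phenyl on the same carbonyl carbon could test. Also open, from the compounds shown here alone, is whether a quite different group there, such as an amine, a carboxylic acid or a longer carbon chain, would give a number clearly apart from those of compound 2 and compound 3.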